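The source may report more compounds than this note shows. Statements on the series, on what has been measured and on what is new or still open speak of the compounds shown alone.

Of the compounds shown here, three sharing one core have been measured in an ADME assay on the whole organism (lung, Mus musculus) for pharmacokinetics, read by LC-MS, at a dose of 30 mg/kg by the oral route; on this read-out lower numbers stand for lower exposure and higher numbers for higher exposure at the dose given. Compound 1 `NCc1cc(Oc2cccc(C(=O)NCCS(N)(=O)=O)c2)nc(C(F)(F)F)c1` gives 540 nM, compound 2 `NCc1cc(Oc2cccc(C(=O)NCCn3cnnn3)c2)nc(C(F)(F)F)c1` gives 3460 nM, and compound 3 `NCc1cc(Oc2cccc(C(=O)N3CC[C@@H](O)C3)c2)nc(C(F)(F)F)c1` gives 9130 nM, the highest of the three numbers and well clear of both others. Compound 4 `NCc1cc(Oc2cccc(C(=O)Nc3ccccc3)c2)nc(C(F)(F)F)c1` differs from compound 3 in one place: anilino in place of 3-hydroxypyrrolidin-1-yl on a carbonyl carbon. Two earlier steps changed the group on this carbonyl carbon, and both moved the number a great deal, namely a 17-fold higher number from compound 1 to compound 3 (1.23 log units; beyond the scatter) and a 2.6-fold higher number from compound 2 to compound 3 (0.42 log units; beyond the scatter). An anilino group has not been measured here, so the direction is uncertain. The expected step is a 1.3-fold lower number from compound 3 to compound 4 (0.12 log units; within the scatter). Compound 4 is therefore estimated at 7000 nM, with a range from 1500 nM to 30000 nM.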

Compound 4, maximal plasma concentration: 10300 nM
The estimate for compound 4 lay 1.5-fold (0.17 log units) below the measured number, and the stated range covers the measured number.
By their numbers in this assay, from the lowest: compound 1; then compound 2; then compounds 3 and 4 (each within the scatter of the next).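

In this assay, the carbonyl carbon accepts two very different groups, anilino and 3-hydroxypyrrolidin-1-yl, with a 1.1-fold higher number from compound 3 to compound 4 (0.05 log units; within the scatter), so neither the oxygen nor the defined stereocentre of the departing group is needed for a high number. With phenyl on the amide-type nitrogen, the number stays clear of the two chains, with a 3.0-fold higher number from compound 2 to compound 4 (0.47 log units; beyond the scatter) and a 19-fold higher number from compound 1 to compound 4 (1.28 log units; beyond the scatter). The amide hydrogen, present in compound 1, compound 2 and compound 4, therefore does not by itself hold the number down.

On these data alone, whether benzylamino or a chlorine on the phenyl ring would keep this level remains open. Nothing here gives a measured reason for these numbers.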